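A few compounds are considered here, and "the series" means these few. Any claim that something is new, unique, unknown or untested is made for them only; others in the source may bear on it.

Measured so far:
Compound 1 `CC(C)N(Cc1cccc(OCCCCCC(=O)O)c1)C(=O)c1ccc(-c2ccoc2)cc1` — in an ADME assay on HepG2 cells (Homo sapiens) for cytotoxicity, read by CellTiter-Glo and resazurin assay, with a stated time of 72 h (on this read-out lower numbers stand for an effect already at smaller amounts and higher numbers for an effect only at larger amounts of compound), compound 1 gives only a limit, > 26000 nM.
Compound 2 `CCOC(=O)CCCCCOc1cccc(CN(C(=O)c2ccc(-c3cccnc3)cc2)C(C)C)c1` — in this assay compound 2 gives only a limit, > 26000 nM.
Compound 3 `CCOC(=O)CCCCCOc1cccc(CN(C(=O)c2ccc(-c3ccoc3)cc2)C(C)C)c1` — in this assay compound 3 gives only a limit, > 26000 nM.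

Compound 3 stands where the whole set stands: every value shown is a limit, namely (the limit of > 26000 nM in this assay, at which 3 of the 3 values shown sit). Compound 4 `CCOC(=O)CCCCCOc1cccc(CN(C(=O)c2ccc(-c3ccc4c(c3)OCCO4)cc2)C(C)C)c1` differs from compound 3 by 2,3-dihydro-1,4-benzodioxin-6-yl in place of furan-3-yl on an aromatic carbon. Going by the values given here, two measured steps touch the same region: a step that the two limits leave unreadable from compound 1 to compound 3 and a step that the two limits leave unreadable from compound 2 to compound 3 both run between limits and give no readable size; the second changes the same aromatic carbon. No step is shown beyond the scatter, so no shift beyond the scatter is expected in this assay. Compound 4 is expected to give 30000 nM (15000 nM to 60000 nM), most likely again as a limit. The step that the limit leaves unreadable from compound 3 to compound 4 is expected to stay unreadable against that limit.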

Compound 4, half-maximal effective concentration: > 24400 nM
Compound 4: no number, only a limit; the forecaster's own chance of this, stated with the estimate: 80%; the middle value lies beyond the limit too.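

No size can be read for the steps to compound 4 from compound 2 or compound 3, since all three give only limits in this assay. Left open is the concentration at which any compound shown reaches a half-maximal effect.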